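The compounds below may be only part of what the source reports. "The series", "measured", "known", "first", "only" and "open" are said of these compounds alone.

In an assay on HUVEC cells for inhibition of transcription factor p65 (Homo sapiens) (a lower number here means a smaller maximal response, a higher number a larger maximal response), compound 1 `Cc1ccc2cccc(NS(=O)(=O)c3ccc(C(F)(F)F)cc3[N+](=O)[O-])c2n1` reaches > 90%, which is a limit of the assay rather than a number. Compound 2 `O=S(=O)(Nc1cccc2cccnc12)c1cccs1` likewise reaches > 90% in this assay, again a limit and not a number. Both values sit at the same edge, as shown by the limit of > 90% in this assay, at which 2 of the 2 values shown sit. Compound 3 `O=S(=O)(Nc1cccc2cccnc12)c1ccc(Cl)s1` differs from compound 2 by chloro in place of hydrogen on an aromatic carbon. For the measured compounds named here, no measured step guides this change, so no shift beyond the scatter is expected, and the step from a step that the limit leaves unreadable from compound 2 to compound 3 is estimated as essentially flat. Compound 3 is therefore expected to show 95% in this assay, within 85% to 100%.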

Compound 3, largest response reached (reported as efficacy), in percent of the reference or control that the assay uses: > 90%
Compound 3: a limit, no number; the forecaster's own chance of this, stated with the estimate: 80%; the middle value is on the limit's open side.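

In this assay, for the compounds shown here, compound 2 and compound 3 both give limits rather than numbers, so no step between them can be read. As far as these compounds go, whether chloro in place of hydrogen changes the response at all stays open.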